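Aryl swap on the sulfonyl sulfur at the assay limit

This account rests on a few compounds, and the source may have more. Where it says the series, first, only, none or still open, it means among the compounds named here.

In an ADME assay on HEK293 cells (Homo sapiens) for antiproliferative activity, read by MTT assay, with a stated time of 48 h (on this read-out higher numbers stand for weaker inhibition and lower numbers for stronger inhibition), compound 1 (`O=C(/C=C/c1cn(S(=O)(=O)c2ccccc2[N+](=O)[O-])c2ccccc12)c1ccncc1`) reads > 150000 nM and this is a limit of the assay. Compound 2 (`O=C(/C=C/c1cn(S(=O)(=O)c2ccc(Cl)cc2Cl)c2ccccc12)c1ccncc1`) reads > 150000 nM and this is also a limit, so compound 2 has no number to stand on. The whole record so far is the limit of > 150000 nM in this assay, at which 2 of the 2 values shown sit, and nothing finer.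

4-(tert-butyl)phenyl in place of 2,4-dichlorophenyl on a sulfonyl sulfur is the full change from compound 2 to compound 3 (`CC(C)(C)c1ccc(S(=O)(=O)n2cc(/C=C/C(=O)c3ccncc3)c3ccccc32)cc1`), which places 4-(tert-butyl)phenyl on the sulfonyl sulfur. Within the data shown here, the one measured step that bears on this change is also an aryl swap on that sulfur. It is a step that the two limits leave unreadable from compound 1 to compound 2 and offers no size to carry over. No shift beyond the scatter is therefore expected in this assay and no direction can be given. The expected step is a step that the limit leaves unreadable from compound 2 to compound 3 on this estimate. For compound 3 the estimated value is 180000 nM with an expected range of 80000 nM to 400000 nM and a report as a limit again is likely.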

Compound 3, half-maximal inhibitory concentration: > 150000 nM
Compound 3: only a limit was reported; the forecaster's own chance of this, stated with the estimate: 75%; the middle value is on the limit's open side.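

In this assay compound 3 reads > 150000 nM, a limit of the assay. Among these compounds, the steps joining compound 1, compound 2 and compound 3 cannot be read, so no new step emerges: the limit of > 150000 nM in this assay, at which 3 of the 3 values shown sit. The compounds shown leave open whether any aryl group on the sulfonyl sulfur gives a numerical value in this assay, and how these three aryl groups rank.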